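Heptyloxy amino alcohols: from methyl to hydroxy

This account rests on a few compounds, and the source may have more. Where it says the series, first, only, none or still open, it means among the compounds named here.

Compound 1 `CCCCCCCOc1ccc(CCC(N)(CO)C(C)C)cc1` and compound 2 `CCCCCCCOc1ccc(CCC(N)(CC)CO)cc1` share the same core and were both tested in a functional assay on the whole organism (T-cell) with Rattus norvegicus as the target, with a stated time of 4 days; on this read-out higher numbers stand for an effect only at larger amounts of compound and lower numbers for an effect already at smaller amounts. Compound 1 gives 4.5 mg/kg, while compound 2 gives 0.044 mg/kg, the lowest of the two numbers. Among the measured compounds shown here, the step of a 100-fold lower number from compound 1 to compound 2 (2.01 log units; beyond the scatter) is large, and it is the only measured step available. Compound 3 `CCCCCCCOc1ccc(CCC(N)(CO)CO)cc1` has not yet been measured; it differs from compound 2 by hydroxy in place of methyl on a saturated chain carbon, two bonds along the chain from an amine nitrogen. For the measured compounds named here, no measured step covers this particular exchange, so the step from compound 1 to compound 2 bears on it only loosely, in that the two compounds already show how much this dose can move with a small change at this chain carbon. For compound 3 a change that stays within the scatter, or a modest shift to a lower number, is expected, with a 1.5-fold lower number from compound 2 to compound 3 (0.17 log units; within the scatter). The estimate for compound 3 is 0.03 mg/kg, within a range from 0.008 mg/kg to 0.12 mg/kg.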

Compound 3, dose for 50% inhibition: 0.014 mg/kg
Compound 3: the middle estimate sits 2.1-fold (0.33 log units) above what was measured; the measured number falls inside the stated range.
By their numbers in this assay, from the lowest: compound 3; then compound 2; then compound 1.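

In this assay, hydroxy in place of methyl on a saturated chain carbon, two bonds along the chain from an amine nitrogen, gives a 3.1-fold lower number from compound 2 to compound 3 (0.50 log units; beyond the scatter), so this exchange, which cut one bond further out reads ethyl to hydroxymethyl, moves the dose beyond the scatter towards smaller amounts. Hydroxymethyl in place of isopropyl on a saturated chain carbon bound to an amine nitrogen and two saturated chain carbons gives a 320-fold lower number from compound 1 to compound 3 (2.51 log units; beyond the scatter), which leaves the hydroxymethyl compound with the lowest number of the three. Nothing at hand says why the dose moves in this way.

Going by these compounds, it remains open how an aminomethyl or a methoxymethyl group would read at this carbon. The compounds shown also leave open whether a longer chain than heptyloxy would keep the dose this low.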